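Trimming ethyl to methyl in compound 1

This account rests on a few compounds, and the source may have more. Where it says the series, first, only, none or still open, it means among the compounds named here.

Among the compounds with values here, in a functional assay on the whole organism with Mus musculus as the target (a higher number here means that more compound is needed for the effect, a lower number that less compound is needed), compound 1 `CCn1nc(-c2ccc(Cl)cc2)n(C)c1=S` gives 100 mg/kg, the only true number so far. For compound 2 `Cn1nc(-c2ccccc2)n(C)c1=O` the reading is a limit, > 200 mg/kg. Compound 3 `Cn1nc(-c2ccc(Cl)cc2)n(C)c1=S` has hydrogen in place of methyl on a saturated chain carbon bound to an aromatic nitrogen, which turns the ethyl of compound 1 into methyl (hydrogen in place of methyl on a saturated chain carbon bound to an aromatic nitrogen). Within the data shown here, no measured pair differs in one place only, so a shift within the usual scatter of this assay is expected, with no firm direction. The expected change is a 1.3-fold lower number from compound 1 to compound 3 (0.10 log units; within the scatter). The estimate for compound 3 is 80 mg/kg, within a range of 30 mg/kg to 200 mg/kg.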

Compound 3, dose for half-maximal effect: 0.27 mg/kg
Compound 3: middle estimate off by 300-fold (2.47 log units), on the high side, and the stated range ends above it.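

At this position, on a saturated chain carbon bound to an aromatic nitrogen, the change from ethyl to methyl removes only one carbon, yet in this assay it gives a 370-fold lower number from compound 1 to compound 3 (2.57 log units; beyond the scatter). Within the data shown here, as the only step that can be read so far, it shows that this position is highly sensitive to a change of a single carbon, which the earlier compounds could not reveal. Nothing at hand accounts for the size of this step. On these data alone, how a propyl chain or a 2-hydroxyethyl group at this position would read in this assay remains open. So does whether the step would hold if the 4-chlorophenyl group were replaced by another group.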